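The source may report more compounds than this note shows. Statements on the series, on what has been measured and on what is new or still open speak of the compounds shown alone.

Among the measured compounds shown here, compound 2 `O=C1O[C@H]([C@@H](O)Cn2cc(CCCCl)nn2)C(OCc2ccccc2)=C1OCc1ccccc1` stands at the higher of the two numbers known so far in an ADME assay on HFF cells (Homo sapiens) for cytotoxicity, read by MTT assay, with a stated time of 72 h; a lower number here means a stronger inhibitor, a higher number a weaker inhibitor: compound 2 gives 27100 nM, whereas compound 1 `O=C1O[C@H]([C@@H](O)Cn2cc(CNS(=O)(=O)c3ccc(Cl)cc3)nn2)C(OCc2ccccc2)=C1OCc1ccccc1` gives 20 nM. For the measured compounds named here, the one measured step, a 1400-fold higher number from compound 1 to compound 2 (3.13 log units; beyond the scatter), shows how much the number moved when the ((4-chlorophenyl)sulfonyl)amino group was replaced by 2-chloroethyl. Compound 3 `COc1ccc(-c2cn(C[C@H](O)[C@H]3OC(=O)C(OCc4ccccc4)=C3OCc3ccccc3)nn2)cc1` is not yet measured; it differs from compound 2 as follows: 4-methoxyphenyl in place of 3-chloropropyl on an aromatic carbon. This bears a loose resemblance to the measured step, in that a group with a six-membered aromatic ring again replaces a short chlorinated chain, but the direction is reversed and the groups and position are not the same. She therefore expects the number to fall, probably by less than the measured step, with a 14-fold lower number from compound 2 to compound 3 (1.13 log units; beyond the scatter). Her estimate for compound 3 is 2000 nM, between 200 nM and 20000 nM.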

Compound 3, half-maximal inhibitory concentration: < 10 nM
Compound 3: only a limit was reported; the forecaster's own chance of this, stated with the estimate: 5%; middle value at least 200-fold (2.30 log units) away from the limit.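

Among the compounds shown here, the earlier step showed only that the number rose when the sulfonyl-bearing side chain gave way to a short chlorinated chain. Here, placing 4-methoxyphenyl in place of 3-chloropropyl on this aromatic carbon gives an at least 2700-fold lower number from compound 2 to compound 3 (3.43 log units; beyond the scatter), so a low number in this assay does not require the ((4-chlorophenyl)sulfonyl)amino group, and among these three compounds only the 3-chloropropyl chain stands far higher. The other comparison, an at least 2.0-fold lower number from compound 1 to compound 3 (0.30 log units; that floor lies within the scatter), does not order the two compounds, and for compound 3 the assay gives only a limit, not a number: the limit of < 10 nM in this assay, at which 1 of the 3 values shown sits.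

The compounds shown leave open how far the true value of compound 3 lies past that limit. They also leave open whether the methoxy group or the aromatic ring itself matters, which an unsubstituted phenyl or a 4-hydroxyphenyl on this carbon would address.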